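Series notes: sulfur-linked substituents on a shared core

The source may hold more compounds than are shown below. What is called first, only, known or untested is meant among the compounds shown, and "the series" means these compounds.

Measured compounds in a functional assay on HT cells (Homo sapiens) for antiproliferative activity, read by fluorescence, with a stated time of 72 h; a higher number here means a weaker inhibitor of growth, a lower number a stronger inhibitor of growth:
- compound 1 `CC(C)c1n[nH]c2c(NCc3ccc(-c4ccccn4)cc3)nc(SCC(N)CN)nc12` gives 480 nM
- compound 2 `CC(C)c1n[nH]c2c(NCc3ccc(-c4ccccn4)cc3)nc(SCC(C)(C)N)nc12` gives 85 nM
- compound 3 `CC(C)c1n[nH]c2c(NCc3ccc(-c4ccccn4)cc3)nc(SC3CCCCC3O)nc12` gives 636 nM

Compound 1 stands second highest of the three numbers in this assay. Its nearest neighbour is compound 3, reached by a 1.3-fold higher number from compound 1 to compound 3 (0.12 log units; within the scatter), which is within the scatter. Its furthest is compound 2, reached by a 5.6-fold lower number from compound 1 to compound 2 (0.75 log units; beyond the scatter), a modest step beyond the scatter. Between the other two, a 7.5-fold higher number from compound 2 to compound 3 (0.87 log units; beyond the scatter) is likewise beyond the scatter.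

The next compound, compound 4 `CC(C)c1n[nH]c2c(NCc3ccc(-c4ccccn4)cc3)nc(SC3CCCC3O)nc12`, has not yet been measured. It differs from compound 1 as follows: 2-hydroxycyclopentyl in place of 2,3-diaminopropyl on a sulfur. Among the measured compounds shown here, only one measured step bears directly on this change, namely a 1.3-fold higher number from compound 1 to compound 3 (0.12 log units; within the scatter), in which 2-hydroxycyclohexyl in place of 2,3-diaminopropyl on a sulfur left the number within the scatter. The change to compound 4 is of the same kind, with a five-membered ring entering rather than a six-membered one. For the measured compounds named here, there is no measured step in this set that separates those two ring sizes, so the expectation for compound 4 rests on compound 3 alone, with its value 636 nM. In this assay the step of a 1.3-fold higher number from compound 1 to compound 4 (0.10 log units; within the scatter) is therefore expected to be small and to stay within the scatter. Compound 4 is estimated at 600 nM, with a range from 250 nM to 1500 nM.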

Compound 4, concentration for 50% growth inhibition: 567 nM
Compound 4: middle estimate off by 1.1-fold (0.02 log units), on the high side; measured number inside the range.
By their numbers in this assay, from the lowest: compound 2; then compounds 1, 4 and 3 (each within the scatter of the next).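

Among the compounds shown here, compound 4 gives the first reading of ring size on this sulfur: in this assay, 2-hydroxycyclopentyl in place of 2-hydroxycyclohexyl gives a 1.1-fold lower number from compound 3 to compound 4 (0.05 log units; within the scatter) and so leaves the number within the scatter. Compound 4 also gives a second hydroxylated ring against 2,3-diaminopropyl, with a 1.2-fold higher number from compound 1 to compound 4 (0.07 log units; within the scatter) again within the scatter, so the two ring sizes and the diamine chain cannot be told apart in this assay, whereas 2-amino-2-methylpropyl stays apart from the five-membered ring, with a 6.7-fold higher number from compound 2 to compound 4 (0.82 log units; beyond the scatter) as a modest step beyond the scatter. No measurement is available that would account for any of these steps.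

The compounds shown do not separate the amine of 2-amino-2-methylpropyl from its branched carbon, a question that a 2-hydroxy-2-methylpropyl chain or an unbranched 2-aminoethyl chain on the same sulfur would address. They also leave open whether a 2-aminocyclopentyl ring would stand with the hydroxylated rings or with compound 2.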